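Replacing the aryl group on the shared core: compound 2 to compound 3

A few compounds are considered here, and "the series" means these few. Any claim that something is new, unique, unknown or untested is made for them only; others in the source may bear on it.

Of the compounds shown here, two with a shared core have been tested in a functional assay on MGC-803 cells (Homo sapiens) for inhibition, read by MTT assay, with a stated time of 72 h; on this read-out lower numbers stand for stronger inhibition and higher numbers for weaker inhibition. Compound 1 `CCc1ccc(NC(=O)CSc2nc(Nc3ccccc3)c3ccccc3n2)cc1` reaches only a limit of the assay, giving > 50000 nM in this assay, and the limit of > 50000 nM in this assay, at which 1 of the 2 values shown sits, marks where that limit sits. Compound 2 `C=CC(=O)Nc1cccc(NC(=O)CSc2nc(Nc3ccccc3C)c3ccccc3n2)c1` gives 30200 nM in this assay, the only number shown among the two values. Compound 3 `C=CC(=O)Nc1cccc(NC(=O)CSc2nc(Nc3ccc(Cl)c(Cl)c3)c3ccccc3n2)c1` differs from compound 2 at one place: 3,4-dichlorophenyl in place of 2-methylphenyl on a nitrogen on an aromatic ring. For the measured compounds named here, no measured step between compounds that differ in one place is available, so the size of such a change cannot be read from a known pair. The account expects a small step from compound 2 to compound 3 toward stronger inhibition, a 2.0-fold lower number from compound 2 to compound 3 (0.30 log units; within the scatter), though a result within the usual scatter is also plausible. Compound 3 is estimated at 15000 nM in this assay, within a range from 4000 nM to 50000 nM.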

Compound 3, half-maximal inhibitory concentration: > 50000 nM
Compound 3: no number, only a limit (the forecaster's own chance of this, stated with the estimate: 25%); middle value at least 3.3-fold (0.52 log units) from the limit.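

In this assay, 3,4-dichlorophenyl in place of 2-methylphenyl on the nitrogen gives the only one-place step shown, an at least 1.6-fold higher number from compound 2 to compound 3 (0.21 log units; that floor lies within the scatter). For compound 3, the value > 50000 nM is a limit of the assay and not a number, so only the floor of the step can be read. This change therefore brings no lower number at this position, and the read-out for most of the compounds shown now ends at a single point: the limit of > 50000 nM in this assay, at which 2 of the 3 values shown sit.

The compounds shown leave open how far above that floor compound 3 lies, and so how large the true step is. They also leave open how this position responds to other groups on the nitrogen, such as unsubstituted phenyl, a phenyl carrying a single chlorine, or a methoxyphenyl, on the core of compound 2.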